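The source may report more compounds than this note shows. Statements on the series, on what has been measured and on what is new or still open speak of the compounds shown alone.

Measured compounds:
Compound 1, `O=C(O)CCC(=O)OCCCCCCSc1ccc([N+](=O)[O-])c2nonc12`, in an assay on isolated protein for inhibition of glutathione S-transferase P (Homo sapiens), with a stated time of 10 min; on this read-out higher numbers stand for weaker inhibition and lower numbers for stronger inhibition: 530 nM
Compound 2, `COc1ccccc1NC(=O)CCC(=O)OCCCCCCSc1ccc([N+](=O)[O-])c2nonc12`, in this assay: 4050 nM
Compound 3, `O=C(CCC(=O)OCCCCCCSc1ccc([N+](=O)[O-])c2nonc12)Nc1ccc(F)cc1`, in this assay: 8570 nM

Compound 3 gives the highest of the three numbers in this assay; compound 2 is nearest to it, and compound 1 furthest, as the steps of a 2.1-fold higher number from compound 2 to compound 3 (0.33 log units; beyond the scatter) and a 16-fold higher number from compound 1 to compound 3 (1.21 log units; beyond the scatter) show. Compound 4, `COc1ccc(NC(=O)CCC(=O)OCCCCCCSc2ccc([N+](=O)[O-])c3nonc23)cc1`, is not yet measured. It differs from compound 3 in one place: methoxy in place of fluoro on an aromatic carbon. Among the measured compounds shown here, no measured step changes fluoro to methoxy on the same carbon. The step of a 2.1-fold higher number from compound 2 to compound 3 (0.33 log units; beyond the scatter) bears on it only loosely, since there the methoxy sits on a different carbon of the ring, and that step was modest. From this single, indirect comparison, a modest fall in the number, or none beyond the scatter, is expected for compound 4 in this assay; the expected step is a 1.6-fold lower number from compound 3 to compound 4 (0.19 log units; within the scatter). The estimate for compound 4 in this assay is 5500 nM, with a range from 2000 nM to 15000 nM.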

Compound 4, half-maximal inhibitory concentration: 420 nM
For compound 4 the middle estimate is 13-fold (1.12 log units) above the measured one, and the stated range ends above it.
By their numbers in this assay, from the lowest: compounds 4 and 1 (each within the scatter of the next); then compound 2; then compound 3.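

In this assay, among the compounds shown here, the exchange of fluoro for methoxy on this aromatic carbon, para to a large group, is a large change (a 20-fold lower number from compound 3 to compound 4 (1.31 log units; beyond the scatter)), so what sits at this position matters far more than the earlier compounds could show. Where the methoxy stands on the ring also weighs heavily: 4-methoxyphenyl in place of 2-methoxyphenyl on the amide nitrogen is a clear step (a 9.6-fold lower number from compound 2 to compound 4 (0.98 log units; beyond the scatter)). Compounds 2 and 3 had suggested that an arylamino group in place of hydroxy raises the number, but compound 4 goes against that pattern, its step from the acid lying within the scatter (a 1.3-fold lower number from compound 1 to compound 4 (0.10 log units; within the scatter)).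

No measurement shown here accounts for these differences. From the compounds shown here alone, how an ethoxy group, a hydroxy group or a chlorine on the same carbon would read in this assay stays open.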